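A few compounds are considered here, and "the series" means these few. Any claim that something is new, unique, unknown or untested is made for them only; others in the source may bear on it.

Of the compounds shown here, three built on one shared core have so far been tested in a functional assay on L1210 cells (Mus musculus) for cytotoxicity, with a stated time of 48 h; on this read-out higher numbers stand for weaker inhibition and lower numbers for stronger inhibition. Compound 1, with the structure `O=C1/C(=C/c2ccc(F)cc2)CCC/C1=C\c1cccc([N+](=O)[O-])c1`, gives 16300 nM in this assay. Compound 2, with the structure `O=C1/C(=C/c2ccc(F)cc2)CCC/C1=C\c1ccc([N+](=O)[O-])cc1`, gives 26800 nM, and compound 3, with the structure `O=C1/C(=C/c2ccc(Cl)cc2)CCC/C1=C\c1ccc([N+](=O)[O-])cc1`, gives 9410 nM. The numbers for compound 1 and compound 2 lie within the usual scatter of each other, as do those for compound 1 and compound 3, so nothing can be said about their order.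

Compound 2 and compound 3 differ in one place only: chloro in place of fluoro on an aromatic carbon. That single exchange gives a 2.8-fold lower number from compound 2 to compound 3 (0.45 log units; beyond the scatter). Compound 1 and compound 2, by contrast, hold the same atoms joined differently, and the difference between the two cores is not broken down here.

Compound 4, with the structure `O=C1/C(=C/c2ccc(Cl)cc2)CCC/C1=C\c1cccc([N+](=O)[O-])c1`, has not yet been measured. It differs from compound 1 by chloro in place of fluoro on an aromatic carbon. The place of the exchange is described in the same words as for the pair of compound 2 and compound 3, so this is the same change, made now in a second pair of compounds. Because the earlier exchange gave a 2.8-fold lower number from compound 2 to compound 3 (0.45 log units; beyond the scatter), a step of similar size is expected here, namely a 2.6-fold lower number from compound 1 to compound 4 (0.42 log units; beyond the scatter). On that basis compound 4 is estimated to give 6200 nM, with the expected range reaching from 3000 nM to 13000 nM.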

Compound 4, half-maximal inhibitory concentration: 9160 nM
For compound 4 the middle estimate is 1.5-fold (0.17 log units) below the measured one, within the range that was stated.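

In this assay, putting chloro in place of fluoro on the core of compound 1, the change from 4-fluorophenyl to 4-chlorophenyl, gives a 1.8-fold lower number from compound 1 to compound 4 (0.25 log units; within the scatter), so this step alone cannot be told apart from the ordinary variation between repeated measurements. Both pairs move in the same direction, and the sizes of their steps cannot be separated, which fits the idea that the exchange carries over from one core to the other: the same change on two cores in this assay, a 2.8-fold lower number (0.45 log units; beyond the scatter) from compound 2 to compound 3 and a 1.8-fold lower number (0.25 log units; within the scatter) from compound 1 to compound 4, 1.6-fold (0.20 log units) apart, within the scatter of two such steps. This does not show that the exchange has a real effect on the core of compound 1 taken alone. Two pairs of compounds are too few to establish a rule for the series.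

The compounds shown carry only fluoro or chloro at this place, so it remains open whether bromo, methyl or methoxy there would follow the same direction. As far as these compounds go, it is also open how the exchange would behave if the nitro group on the other aromatic ring gave way to an amine or a carboxylic acid.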